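Triazole substituent swap on the shared core

The source may hold more compounds than are shown below. What is called first, only, known or untested is meant among the compounds shown, and "the series" means these compounds.

Compound 1 `CCCCCc1ccc(-c2cn(C[C@H](O)[C@H]3OC(=O)C(OCc4ccccc4)=C3OCc3ccccc3)nn2)cc1` gives 7460 nM in a functional assay on HepG2 cells (Homo sapiens) for antiproliferative activity, read by MTT assay, with a stated time of 72 h; a lower number here means a stronger inhibitor, a higher number a weaker inhibitor.
Compound 2 `CC(C)(C)c1cn(C[C@H](O)[C@H]2OC(=O)C(OCc3ccccc3)=C2OCc2ccccc2)nn1` gives 29200 nM in this assay.

Compound 2 stands at the higher of the two numbers, with compound 1 at a 3.9-fold higher number from compound 1 to compound 2 (0.59 log units; beyond the scatter) relative to it. Compound 3 `O=C1O[C@H]([C@@H](O)Cn2cc(-c3cc(F)cc(F)c3)nn2)C(OCc2ccccc2)=C1OCc1ccccc1` carries 3,5-difluorophenyl in place of tert-butyl on an aromatic carbon. Going by the values given here, the only step that bears on it is the one from compound 1 to compound 2, a 3.9-fold higher number from compound 1 to compound 2 (0.59 log units; beyond the scatter), where an aryl group gave way to tert-butyl; restoring an aryl group, though a different one, is expected to move the number back part of that way, a modest drop of a 2.2-fold lower number from compound 2 to compound 3 (0.35 log units; beyond the scatter). Compound 3 is therefore estimated at 13000 nM, within 4500 nM to 38000 nM.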

Compound 3, half-maximal inhibitory concentration: 11600 nM
Compound 3: middle estimate off by 1.1-fold (0.05 log units), on the high side; measured number inside the range.
By their numbers in this assay, from the lowest: compounds 1 and 3 (each within the scatter of the next); then compound 2.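

In this assay the move from tert-butyl to a second aryl group gives a 2.5-fold lower number from compound 2 to compound 3 (0.40 log units; beyond the scatter) and so repeats the direction of the earlier step with a different ring. Between the two aryl groups, a 1.6-fold higher number from compound 1 to compound 3 (0.19 log units; within the scatter) shows that 3,5-difluorophenyl and 4-pentylphenyl cannot be told apart at this aromatic carbon, although one carries two fluorines and the other a pentyl chain. Nothing available explains the separation of tert-butyl from these aryl groups.

Going by these compounds, whether an unsubstituted phenyl would stay level with these two remains open. So does the outcome of an aryl ring carrying an amine or a carboxylic acid.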